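Swapping the Aminophenyl for a Difluorophenyl Group

The source may hold more compounds than are shown below. What is called first, only, known or untested is meant among the compounds shown, and "the series" means these compounds.

In a functional assay on NCI-H322M cells (Homo sapiens) for cytotoxicity, read by sulforhodamine B assay, with a stated time of 48 h, tested at 10 uM (a higher number here means a weaker effect of the compound at the concentration tested, a lower number a stronger effect), the three measured compounds gave these numbers:

Compound 1, `COc1cc(-c2cc(/C=C/C(=O)c3ccc(N)cc3)[nH]n2)cc(OC)c1OC`: -32%
Compound 2, `COc1cc(-c2cc(/C=C/C(=O)c3ccc(Cl)c(Cl)c3)[nH]n2)cc(OC)c1OC`: 59%
Compound 3, `COc1ccc(C(=O)/C=C/c2cc(-c3cc(OC)c(OC)c(OC)c3)n[nH]2)cc1`: -60%

Compound 1 stands second highest of the three. Its nearest neighbour is compound 3, reached by a number 28 percentage points lower from compound 1 to compound 3 (beyond the scatter); its furthest is compound 2, reached by a number 91 percentage points higher from compound 1 to compound 2 (beyond the scatter).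

Compound 4, `COc1cc(-c2cc(/C=C/C(=O)c3ccc(F)c(F)c3)[nH]n2)cc(OC)c1OC`, differs from compound 1 in one place: 3,4-difluorophenyl in place of 4-aminophenyl on a carbonyl carbon.

For the measured compounds named here, the step that bears most on this change is the one to compound 2, where another halogenated phenyl took the place of the aminophenyl on the same carbonyl carbon and the number rose by a large margin, a number 91 percentage points higher from compound 1 to compound 2 (beyond the scatter). The step of a number 119 percentage points lower from compound 2 to compound 3 (beyond the scatter), in which that dichlorophenyl gave way to a methoxyphenyl, moved the number sharply the other way. Both point to a rise when the aminophenyl is replaced by a halogenated ring, so compound 4 is expected to read higher than compound 1, by a step estimated at a number 52 percentage points higher from compound 1 to compound 4 (beyond the scatter), though with two fluorines rather than two chlorines the size is uncertain. Compound 4 is therefore estimated at 20%, within a range from -30% to 60%.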

Compound 4, a percentage reported as activity, at one concentration (the size of the read-out at that concentration, not a potency): 18%
Beside the measured number, compound 4's estimate is 2 percentage points above it, within the range that was stated.
By their numbers in this assay, from the lowest: compound 3; then compound 1; then compound 4; then compound 2.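

Replacing the 4-aminophenyl on the carbonyl carbon with 3,4-difluorophenyl gives a number 50 percentage points higher from compound 1 to compound 4 (beyond the scatter), and replacing the 4-methoxyphenyl with it gives a number 78 percentage points higher from compound 3 to compound 4 (beyond the scatter). A second halogenated ring therefore goes the same way as the 3,4-dichlorophenyl: among these four compounds, both halogenated rings read higher, meaning a weaker effect, than the rings carrying amino or methoxy, and no compound shown goes against this. The choice of halogen also counts, since exchanging 3,4-dichlorophenyl for 3,4-difluorophenyl gives a number 41 percentage points lower from compound 2 to compound 4 (beyond the scatter), so the two halogenated rings are not interchangeable at this position.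

For the compounds shown here, nothing available explains why the ring on the carbonyl carbon moves the number so far. It also remains open where a phenyl ring carrying a single fluorine, a dimethylamino group or a carboxylic acid would fall among these four compounds.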